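A Thiophene Ring Replaces the Phenylethynyl Arm

The source may hold more compounds than are shown below. What is called first, only, known or untested is meant among the compounds shown, and "the series" means these compounds.

Three compounds have been measured in a functional assay on Z-138 cells (Homo sapiens) for antiproliferative activity, with a stated time of 72 h; on this read-out higher numbers stand for weaker inhibition and lower numbers for stronger inhibition:
Compound 1 `Nc1ncnn2c([C@@H]3O[C@H](CO)[C@@H](O)[C@H]3O)cc(C#Cc3ccccc3)c12` gives 41400 nM.
Compound 2 `Nc1ncnn2c([C@@H]3O[C@H](CO)[C@@H](O)[C@H]3O)cc(-c3ccccc3)c12` reaches only a limit of the assay, > 100000 nM.
Compound 3 `Nc1ncnn2c([C@@H]3O[C@H](CO)[C@@H](O)[C@H]3O)cc(/C=C/c3ccccc3)c12` gives 1300 nM.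

Compound 1 holds the highest of the two numbers shown; the only other number lies below it, reached in the step of a 32-fold lower number from compound 1 to compound 3 (1.50 log units; beyond the scatter). The unmeasured compound 4 `Nc1ncnn2c([C@@H]3O[C@H](CO)[C@@H](O)[C@H]3O)cc(-c3ccsc3)c12` differs from compound 1 in one place: thiophen-3-yl in place of 2-phenylethynyl on an aromatic carbon. The step that bears on this is an at least 2.4-fold higher number from compound 1 to compound 2 (0.38 log units; beyond the scatter), which ended at the limit (the limit of > 100000 nM in this assay, at which 1 of the 3 values shown sits). For compound 4 a higher number is therefore expected, a 1.9-fold higher number from compound 1 to compound 4 (0.29 log units; within the scatter). Compound 4 is estimated at 80000 nM, within 20000 nM to 300000 nM.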

Compound 4, half-maximal inhibitory concentration: 43500 nM
The estimate for compound 4 lay 1.8-fold (0.26 log units) above the measured number, and the stated range covers the measured number.
By their numbers in this assay, from the lowest: compound 3; then compounds 1 and 4 (each within the scatter of the next). At a limit, above all of these: compound 2.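

In this assay, thiophen-3-yl on this aromatic carbon cannot be told apart from the 2-phenylethynyl arm, with a 1.1-fold higher number from compound 1 to compound 4 (0.02 log units; within the scatter). The change from 2-phenylethenyl costs far more, with a 33-fold higher number from compound 3 to compound 4 (1.52 log units; beyond the scatter), so the gain seen with that arm does not carry over to this ring. Against phenyl there is an at least 2.2-fold lower number from compound 2 to compound 4 (0.36 log units; beyond the scatter), which gives only a bound, since compound 2 stands at a limit: the limit of > 100000 nM in this assay, at which 1 of the 4 values shown sits.

On these data alone, what remains open is how an amine, a carboxylic acid or a furan ring would behave on this carbon. The compounds shown also leave open whether thiophen-2-yl would match thiophen-3-yl.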